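Methoxy for Chloro: Expected Cytotoxicity of Compound 3

The source may report more compounds than this note shows. Statements on the series, on what has been measured and on what is new or still open speak of the compounds shown alone.

Among the compounds with values here, compound 2 `Cc1ccc2nc(NC(=O)c3cn(-c4ccccc4)nc3-c3ccc(Cl)cc3)sc2c1` is one of two compounds measured in an ADME assay on HEK-293T cells (Homo sapiens) for cytotoxicity, read by MTT assay, with a stated time of 72 h; on this read-out lower numbers stand for stronger inhibition and higher numbers for weaker inhibition. In this assay, within the data shown here, compound 2 gives 35600 nM, the only number reported among the two. Compound 1 `O=C(Nc1nc2ccc(F)cc2s1)c1cn(-c2ccccc2)nc1-c1ccc(Cl)cc1` reaches only a limit of the assay, giving > 50000 nM in this assay. The step of an at least 1.4-fold lower number from compound 1 to compound 2 (0.14 log units; that floor lies within the scatter) is bounded by the limit of > 50000 nM in this assay, at which 1 of the 2 values shown sits, so its true size is not known. Compound 3 `COc1ccc(-c2nn(-c3ccccc3)cc2C(=O)Nc2nc3ccc(C)cc3s2)cc1` is not yet measured; it differs from compound 2 by methoxy in place of chloro on an aromatic carbon. Among the measured compounds shown here, no measured step touches this group: the only measured step, an at least 1.4-fold lower number from compound 1 to compound 2 (0.14 log units; that floor lies within the scatter), alters a different group and sits at a floor within the scatter, so it offers no guide to the direction or size of the change from chloro to methoxy. With nothing in the data pointing either way, the expected step for compound 3 in this assay is none beyond the scatter. Compound 3 is therefore estimated at 38000 nM, within 15000 nM to 100000 nM, in this assay. The expected step of a 1.1-fold higher number from compound 2 to compound 3 (0.03 log units; within the scatter) lies within the scatter, with a real chance that only a limit is reported.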

Compound 3, half-maximal inhibitory concentration: > 50000 nM
Compound 3 was reported as a limit (the forecaster's own chance of this, stated with the estimate: 40%); middle value at least 1.3-fold (0.11 log units) away from the limit.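

Within the data shown here, the change from 4-chlorophenyl to 4-methoxyphenyl gives the first reading at this position, which the earlier step on the other side of the molecule could not provide. In this assay, methoxy in place of chloro on an aromatic carbon, para to a large group, comes out as an at least 1.4-fold higher number from compound 2 to compound 3 (0.14 log units; that floor lies within the scatter), so this reading shows no change beyond the scatter, while leaving open that the real change is larger. Compound 3 gives > 50000 nM, which is a limit of the assay, and the size of the step therefore cannot be read, only its floor, with the series now resting mostly on that one boundary: the limit of > 50000 nM in this assay, at which 2 of the 3 values shown sit.

The compounds shown leave open how far the value of compound 3 lies from that of compound 2, and whether any replacement of chloro at this place gives a number clearly apart from that of compound 2. An amine or a carboxylic acid on the same aromatic carbon would test this further, as would a longer chain in place of the methoxy.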